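A few compounds are considered here, and "the series" means these few. Any claim that something is new, unique, unknown or untested is made for them only; others in the source may bear on it.

Measured so far:
compound 1 `CCCCNC(=O)OC/C=C(\C)C1=CC(=O)C(C)(C)O1` — 5.3 ug/mL
compound 2 `C/C(=C\C=C/C1CCCCC1)C1=CC(=O)C(C)(C)O1` — 7.1 ug/mL

In a functional assay on MOLT-4F cells (Homo sapiens) for inhibition (a higher number here means a weaker inhibitor, a lower number a stronger inhibitor), compound 1 gives 5.3 ug/mL. Compound 2 gives 7.1 ug/mL in this assay, and the two values lie within the usual scatter of each other, so neither stands apart. Compound 3 `C/C(=C\COC(=O)NC1CCCCC1)C1=CC(=O)C(C)(C)O1` is not yet measured. It differs from compound 1 in one place: cyclohexyl in place of butyl on an amide-type nitrogen. Among the compounds with values here, no measured pair shows this change, so its step size is unknown. With the rest of the molecule unchanged, the expected step is a 1.0-fold higher number from compound 1 to compound 3 (0.02 log units; within the scatter), none beyond the scatter. For compound 3 the estimated value in this assay is 5.5 ug/mL, between 2.5 ug/mL and 12 ug/mL.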

Compound 3, half-maximal inhibitory concentration: 3.4 ug/mL
Compound 3: the middle estimate sits 1.6-fold (0.21 log units) above what was measured; low and high end bracket the measured number.
By their numbers in this assay, from the lowest: compounds 3, 1 and 2 (each within the scatter of the next, the first and the last beyond it).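

On the amide-type nitrogen, cyclohexyl in place of butyl gives a 1.6-fold lower number from compound 1 to compound 3 (0.19 log units; within the scatter) in this assay and thus stays within the scatter. Within the data shown here, this is the first measured step at this position, and it shows that a six-membered carbon ring and an open butyl chain read alike here. Nothing measured bears on why the two groups read alike.

Still open, going by these compounds, is whether phenyl, a longer chain such as octyl, or a chain ending in a carboxylic acid or an amine would move the number beyond the scatter. A step of that kind would show whether this position matters at all in this assay.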